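Aryl swap on the five-membered ring of compound 2

The source may report more compounds than this note shows. Statements on the series, on what has been measured and on what is new or still open speak of the compounds shown alone.

Three compounds of the series have been run in a functional assay on BJAB cells (Homo sapiens) for antiproliferative activity, with a stated time of 4 days; on this read-out lower numbers stand for an effect already at smaller amounts and higher numbers for an effect only at larger amounts of compound. Compound 1 `Cc1c(-c2cc(Cl)cc(Cl)c2)c(C(=O)O)nn1-c1nc(-c2cnn(C)c2)c(SC(C)C)s1` gives "not active" (no number reported). Compound 3 `Cc1c(-c2cc(Cl)cc(Cl)c2)c(C(=O)O)nn1-c1nc(-c2ccncc2)c(SC(C)C)s1` likewise gives "not active" (no number reported). Within the data shown here, compound 2 `Cc1nn(-c2nc(-c3ccc(Cl)c(Cl)c3)c(SC(C)C)s2)c(C(=O)O)c1-c1cnn(C)c1` gives 6800 nM in this assay and so stands as the only compound with a number; the other two entries carry no number at all, so no step between measured compounds can be read from this set.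

Compound 4 `COc1ccccc1-c1c(C)nn(-c2nc(-c3ccc(Cl)c(Cl)c3)c(SC(C)C)s2)c1C(=O)O` is the next entry for this assay. It differs from compound 2 in one place: 2-methoxyphenyl in place of 1-methyl-1H-pyrazol-4-yl on an aromatic carbon. Nothing in the measured compounds shows how a change at this position moves the read-out, so no direction is supported by data. The expected step from compound 2 to compound 4 is a 1.5-fold higher number from compound 2 to compound 4 (0.17 log units; within the scatter), a modest shift with wide uncertainty and a real chance that only a limit is returned. For compound 4 the estimate is 10000 nM, within 3000 nM to 30000 nM.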

Compound 4, half-maximal effective concentration: 14700 nM
Estimate against measurement, compound 4: 1.5-fold (0.17 log units) below, within the range that was stated.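

In this assay, the position on the five-membered aromatic ring with 2 nitrogen, next to the ring atom that bears a carboxy group, now has its first readable step: replacing 1-methyl-1H-pyrazol-4-yl with 2-methoxyphenyl gives a 2.2-fold higher number from compound 2 to compound 4 (0.33 log units; beyond the scatter). The step is modest, but it lies beyond the usual scatter, and a measured number remains with a six-membered aromatic ring of carbon only at this position. No measured information on the two groups accounts for the step.

Among these compounds, compound 1 and compound 3 carry no number, so no steps involving them can be read. On these data alone, it remains open whether an unsubstituted phenyl or a 2-hydroxyphenyl at this position would track compound 2 or compound 4 in this read-out, and whether an amine on the aryl ring would shift the number further.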